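Hydrogen in place of chloro: compound 3 to compound 4

The compounds below may be only part of what the source reports. "The series", "measured", "known", "first", "only" and "open" are said of these compounds alone.

Three compounds have so far been measured in a functional assay on the whole organism (strain Swiss albino) with Mus musculus as the target, with a stated time of 0.5 h; on this read-out lower numbers stand for an effect already at smaller amounts and higher numbers for an effect only at larger amounts of compound:

compound 1 `O=[N+]([O-])c1ccc(/C=N/Cc2cccnc2)cc1` gives 30 mg/kg
compound 2 `C(=N/Cc1cccnc1)\c1c[nH]c2ccccc12` gives 300 mg/kg
compound 3 `Clc1ccccc1/C=N/Cc1cccnc1` gives 100 mg/kg

Among these three numbers compound 3 stands second highest. Compound 2 sits above it with a higher number, and compound 1 sits below it with a lower number; both of these gaps lie beyond the usual scatter of this kind of measurement, so the three compounds are genuinely spread apart on this read-out.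

Compound 4 `C(=N/Cc1cccnc1)\c1ccccc1` has not yet been measured. It differs from compound 3 in one place only:

hydrogen in place of chloro on an aromatic carbon

Within the data shown here, the three measured compounds differ from one another at several places at once, so no measured pair shows what a single change of this kind does on this read-out. The shared core carrying the pyridine-bearing chain is the same in all four compounds, and only the substituent on the six-membered aromatic ring of carbon only changes between compound 3 and compound 4.

With nothing to compare against, the step of no change at the digits printed from compound 3 to compound 4 (within the scatter) is expected to stay within the scatter, with no clear direction. Compound 4 is therefore estimated at 100 mg/kg, within a range from 50 mg/kg to 300 mg/kg.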

Compound 4, minimum effective dose: 100 mg/kg
The estimate for compound 4 equals the measured number at the digits printed; measured number inside the range.
By their numbers in this assay, from the lowest: compound 1; then compounds 3 and 4 (each within the scatter of the next); then compound 2.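

In this assay, the pair compound 3 and compound 4 isolates one place, the aromatic carbon ortho to a group of 9 heavy atoms, and the step with hydrogen in place of chloro there reads no change at the digits printed from compound 3 to compound 4 (within the scatter) on this read-out, so chloro and hydrogen at this place cannot be told apart. Compound 4 also forms a second pair that differs in one place, and with hydrogen in place of nitro the step reads a 3.3-fold higher number from compound 1 to compound 4 (0.52 log units; beyond the scatter) and thus shows that a single substituent on this ring can shift the minimum effective dose, with the nitro of compound 1 on the side of the lower number. No accompanying measurement accounts for either step.

These two pairs do not show whether a different group at the place held by chloro, such as an amine or a methoxy group, would also stay within the scatter of compound 4. They also leave open whether the lower number of compound 1 is specific to nitro, or whether another group on the same carbon, such as a nitrile or a carboxylic acid, would give a similar step.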